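Mirror-image pair in a small series

The source may hold more compounds than are shown below. What is called first, only, known or untested is meant among the compounds shown, and "the series" means these compounds.

- compound 1 `CC1=NN(c2ccccc2)C(=O)[C@]12C(=O)C=CC[C@@H]2c1ccc(C)cc1`: 5800 nM
- compound 2 `CC1=NN(c2ccc(C)cc2)C(=O)[C@@]12C(=O)C=CC[C@H]2c1ccc(C)cc1`: 3620 nM

In a functional assay on HCT-116 cells (Homo sapiens) for inhibition, read by MTT assay, with a stated time of 72 h (on this read-out lower numbers stand for stronger inhibition and higher numbers for weaker inhibition), compound 2 gives 3620 nM, which lies within the scatter of compound 1 at 5800 nM, so the two cannot be ranked.

The open question is compound 3 `CC1=NN(c2ccc(C)cc2)C(=O)[C@]12C(=O)C=CC[C@@H]2c1ccc(C)cc1`. Relative to compound 2, the change is the two compounds have the same atoms and bonds and differ only in configuration as drawn: 2 of 2 stereo elements differ (all stereocentres are inverted: mirror images); a stereocentre at a saturated ring carbon is drawn R in compound 2 and S in compound 3; a stereocentre at a saturated ring carbon is drawn S in compound 2 and R in compound 3: the two compounds are mirror images, with the same atoms and bonds.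

Among the measured compounds shown here, no measured pair here isolates such an inversion, so the data give no size for it. In this assay, for the measured compounds named here, no step clearly beyond the scatter is expected, with only a slight, insecure lean towards a higher number. The estimate amounts to an expected 1.3-fold higher number from compound 2 to compound 3 (0.12 log units; within the scatter). The estimated value for compound 3 is 4800 nM, with an expected range of 1800 nM to 12000 nM.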

Compound 3, half-maximal inhibitory concentration: 14600 nM
Beside the measured number, compound 3's estimate is 3.0-fold (0.48 log units) below it; measured number outside the range, above it.
By their numbers in this assay, from the lowest: compounds 2 and 1 (each within the scatter of the next); then compound 3.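

In this assay the configuration as drawn proves to matter in this series, with a 4.0-fold higher number from compound 2 to compound 3 (0.61 log units; beyond the scatter) and no atom or bond altered. The gap can be assigned to configuration alone because nothing else separates the pair: the fact that compounds 2 and 3 differ only in the configuration as drawn. With configuration held constant, methyl in place of hydrogen on an aromatic carbon also registers, giving a 2.5-fold higher number from compound 1 to compound 3 (0.40 log units; beyond the scatter), so this methyl change is not neutral in that configuration.

The compounds shown leave open which of the two stereocentres accounts for the mirror-image gap, since both are inverted together, and whether the methyl step keeps its size and direction in the opposite configuration. Also open, going by these compounds, is how a methoxy group or a carboxylic acid in place of that methyl would read out.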